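Cytotoxicity of a triazole-pyridine urea series in fibroblasts

The source may report more compounds than this note shows. Statements on the series, on what has been measured and on what is new or still open speak of the compounds shown alone.

Three members of the series have been run through an ADME assay on WI-38 cells (Homo sapiens) for cytotoxicity, read by MTT assay, with a stated time of 72 h; on this read-out higher numbers stand for weaker inhibition and lower numbers for stronger inhibition. Compound 1 `CCN(CC)CCn1cnnc1-c1cc(Oc2ccc(NC(=O)Nc3ccc(Cl)c(C(F)(F)F)c3)cc2F)ccn1` gives 6730 nM in this assay. Compound 2 `CCN(CC)CCn1cnnc1-c1cc(Oc2ccc(NC(=O)Nc3cccc(C(F)(F)F)c3)cc2F)ccn1` gives 6920 nM in this assay, and compound 3 `CN(C)CCCn1cnnc1-c1cc(Oc2ccc(NC(=O)Nc3ccc(Cl)c(C(F)(F)F)c3)cc2F)ccn1` gives 7910 nM in this assay. Compound 1 and compound 2 differ by hydrogen in place of chloro on an aromatic carbon; the step of a 1.0-fold higher number from compound 1 to compound 2 (0.01 log units; within the scatter). Compound 1 and compound 3 differ in the chain on the triazole nitrogen, ((dimethylamino)methyl in place of diethylamino on a saturated chain carbon, two bonds along the chain from an aromatic nitrogen), and the step of a 1.2-fold higher number from compound 1 to compound 3 (0.07 log units; within the scatter). The three values sit together in this assay and no ranking among them is claimed.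

Compound 4 `CN(C)CCCn1cnnc1-c1cc(Oc2ccc(NC(=O)Nc3cccc(C(F)(F)F)c3)cc2F)ccn1` has not yet been measured in this assay. It differs from compound 3 by hydrogen in place of chloro on an aromatic carbon. The place line of this change is the same word for word as that of the change from compound 1 to compound 2, so it is the same change on the core of compound 3. Among the measured compounds shown here, because the step of a 1.0-fold higher number from compound 1 to compound 2 (0.01 log units; within the scatter) was flat, the expected step of a 1.0-fold higher number from compound 3 to compound 4 (0.00 log units; within the scatter) is also taken as flat, resting on the single earlier pair. Compound 4 is therefore expected to give 8000 nM in this assay, estimated to fall between 4500 nM and 14000 nM.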

Compound 4, half-maximal inhibitory concentration: 11600 nM
Beside the measured number, compound 4's estimate is 1.5-fold (0.16 log units) below it; measured number inside the range.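

In this assay, hydrogen in place of chloro gives a 1.5-fold higher number from compound 3 to compound 4 (0.17 log units; within the scatter), and (dimethylamino)methyl in place of diethylamino gives a 1.7-fold higher number from compound 2 to compound 4 (0.22 log units; within the scatter). Hydrogen in place of chloro reads alike on the two cores: the same change on two cores in this assay, a 1.0-fold higher number (0.01 log units; within the scatter) from compound 1 to compound 2 and a 1.5-fold higher number (0.17 log units; within the scatter) from compound 3 to compound 4, 1.4-fold (0.15 log units) apart, within the scatter of two such steps. Among the compounds shown here, the chain change also reads alike on its two cores, though two cores give no rule for the wider series and steps of this size show no effect of either change, so the agreement says only that no difference between cores is resolved here: the same change on two cores in this assay, a 1.2-fold higher number (0.07 log units; within the scatter) from compound 1 to compound 3 and a 1.7-fold higher number (0.22 log units; within the scatter) from compound 2 to compound 4, 1.4-fold (0.15 log units) apart, within the scatter of two such steps.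

The compounds shown leave open how the series responds to other groups at that aromatic carbon, such as fluoro, methoxy or a nitrile, and to other chain ends, such as a pyrrolidine, a morpholine or a longer chain. On these data alone, whether any such group would give a step beyond the scatter, and whether that step would then carry from one core to another, also stays open.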